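Series notes: ester variation at the acetoxy position

The source may hold more compounds than are shown below. What is called first, only, known or untested is meant among the compounds shown, and "the series" means these compounds.

Measured so far in a functional assay on MDA-MB-231 cells (Homo sapiens) for antiproliferative activity, read by MTT assay, with a stated time of 72 h; a lower number here means a stronger inhibitor, a higher number a weaker inhibitor:
compound 1 `CC(=O)O[C@H]1CC[C@]2(C)[C@H](CC[C@@](C)(O)[C@H]2CC[C@@H]2C(C)=CC[C@H]3[C@H](CC[C@]3(C)O)C2(C)C)OC1(C)C`: 38000 nM
compound 2 `CC1=CC[C@H]2[C@@H]1CC=C(C)[C@@H](CC[C@H]1[C@]3(C)CC[C@H](OC(=O)CCC(=O)O)C(C)(C)O[C@H]3CC[C@@]1(C)O)C2(C)C`: 29600 nM
compound 3 `CC1=CC[C@H]2[C@H](CC[C@]2(C)O)C(C)(C)[C@@H]1CC[C@H]1[C@]2(C)CC/C(=N/O)C(C)(C)O[C@H]2CC[C@@]1(C)O`: 42700 nM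

On these three numbers compound 1 stands second highest, with compound 3 as its nearest neighbour and compound 2 as its furthest; both gaps fall within the usual scatter of this assay, so the three compounds are not separated from one another by the data shown. Among the compounds with values here, no single-change step between measured compounds is available, so the series gives no direct measure of how a change at the ester carbonyl moves the number.

Compound 4 `CC1=CC[C@H]2[C@H](CC[C@]2(C)O)C(C)(C)[C@@H]1CC[C@H]1[C@]2(C)CC[C@H](OC(=O)c3cccc(C(F)(F)F)c3)C(C)(C)O[C@H]2CC[C@@]1(C)O` departs from compound 1 by one change: 3-(trifluoromethyl)phenyl in place of methyl on a carbonyl carbon. The rest of the shared core is unchanged. Within the data shown here, with no measured step of this kind to lean on, and with the three measured values of compounds 1, 2 and 3 sitting close together, the expectation for compound 4 is a step of a 1.5-fold lower number from compound 1 to compound 4 (0.18 log units; within the scatter), small and not clearly beyond the scatter. The value of compound 4 in this assay is estimated at 25000 nM, expected to lie between 8000 nM and 80000 nM.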

Compound 4, half-maximal inhibitory concentration: 36300 nM
Compound 4: middle estimate off by 1.5-fold (0.16 log units), on the low side; low and high end bracket the measured number.
By their numbers in this assay, from the lowest: compounds 2, 4, 1 and 3 (each within the scatter of the next).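

Working from this assay, the series now has its first single-change step: 3-(trifluoromethyl)phenyl in place of methyl on a carbonyl carbon gives a 1.0-fold lower number from compound 1 to compound 4 (0.02 log units; within the scatter) and stays within the scatter. At this position, then, replacing methyl with a much larger group that includes an aromatic ring leaves the number unresolved from that of compound 1, so this large change in size registers no measurable shift in this read-out. No measurement at hand accounts for this result.

From the compounds shown here alone, it remains open whether any group on this carbonyl carbon can move the number beyond the scatter, since a single aromatic replacement cannot settle that. An unsubstituted phenyl, a longer alkyl chain or a chain ending in an amine would each test this further.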